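Removing the fluoro substituent: compound 3 to compound 4

The compounds below may be only part of what the source reports. "The series", "measured", "known", "first", "only" and "open" are said of these compounds alone.

Within the data shown here, compound 3 `O=C(CCN1CC=C(c2ccc(F)cc2)CC1)c1ccccc1` gives 4 nM in an assay on cerebellum (Cavia porcellus) for binding affinity to Sigma non-opioid intracellular receptor 1 (Homo sapiens), in the presence of a further agent that is not named here (a lower number here means a stronger inhibitor, a higher number a weaker inhibitor), and stands lowest of the three numbers measured so far. The nearest of the others is compound 2 `O=C(CCN1CC=C(c2ccc(Cl)cc2)CC1)c1ccc(Cl)cc1` with 158 nM, the furthest compound 1 `O=C(CCN1CC=C(c2ccc(Cl)cc2)CC1)c1ccccc1F` with 400 nM. Among the measured compounds shown here, the only single-change step measured, a 2.5-fold lower number from compound 1 to compound 2 (0.40 log units; beyond the scatter), concerns the ring on the carbonyl carbon. Compound 4 `O=C(CCN1CC=C(c2ccccc2)CC1)c1ccccc1` differs from compound 3 by hydrogen in place of fluoro on an aromatic carbon, which sits on the other aromatic ring, away from the carbonyl. For the measured compounds named here, compound 1 and compound 2 each differ from compound 3 in two places, so their values give no single-change comparison for this ring, and no measured step bears directly on the change. With nothing pointing to a large effect of a single fluoro on this ring, a step not beyond the scatter is expected, in either direction. For compound 4 the estimate in this assay is 6 nM, with a range from 2 nM to 20 nM. The expected step of a 1.5-fold higher number from compound 3 to compound 4 (0.18 log units; within the scatter) is thus within the usual scatter.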

Compound 4, half-maximal inhibitory concentration: 8 nM
Compound 4: middle estimate off by 1.3-fold (0.12 log units), on the low side; the measured number falls inside the stated range.
By their numbers in this assay, from the lowest: compounds 3 and 4 (each within the scatter of the next); then compound 2; then compound 1.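

In this assay, among these compounds, the 4-fluorophenyl to phenyl change gives a 2.0-fold higher number from compound 3 to compound 4 (0.30 log units; within the scatter), the first single-change reading on the ring away from the carbonyl. Fluoro and hydrogen at this place on the aromatic ring therefore cannot be told apart in this series, and compound 4 at 8 nM shows that the low number does not depend on the fluoro. No supporting data bear on why the change leaves the number within the scatter.

Compound 1 and compound 2 carry a 4-chlorophenyl ring but differ from compound 3 in two places, so the large gaps to compound 3 cannot be assigned to either ring. On these data alone, it also remains open whether a methoxy, an amine or a carboxylic acid at this place on the ring would be tolerated as well as fluoro.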